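A few compounds are considered here, and "the series" means these few. Any claim that something is new, unique, unknown or untested is made for them only; others in the source may bear on it.

Measured so far in a functional assay on 143B cells (Homo sapiens) for antiproliferative activity, read by MTT assay, with a stated time of 48 h; on this read-out lower numbers stand for stronger inhibition and higher numbers for weaker inhibition:
Compound 1 `O=C(Nc1cccc(/C=C/C(=O)c2nc3ccccc3[nH]2)c1)c1ccccc1`: 8340 nM
Compound 2 `O=C(/C=C/c1cccc(NC(=O)c2ccccc2Cl)c1)c1nc2ccccc2[nH]1`: 3690 nM
Compound 3 `Cc1ccccc1C(=O)Nc1cccc(/C=C/C(=O)c2nc3ccccc3[nH]2)c1`: 8290 nM

Compound 3 stands second highest of the three numbers. The step of a 1.0-fold lower number from compound 1 to compound 3 (0.00 log units; within the scatter) lies within the scatter, so compound 1 and compound 3 cannot be told apart, while a 2.2-fold higher number from compound 2 to compound 3 (0.35 log units; beyond the scatter) is a modest rise. The next compound, compound 4 `O=C(Nc1cccc(/C=C/C(=O)c2nc3ccccc3[nH]2)c1)c1cc(Cl)cc(Cl)c1`, differs from compound 3 by 3,5-dichlorophenyl in place of 2-methylphenyl on a carbonyl carbon. Among the compounds with values here, two measured steps bear on this: a 2.3-fold lower number from compound 1 to compound 2 (0.35 log units; beyond the scatter) shows chloro entering in place of hydrogen lowered the number modestly, and a 2.2-fold higher number from compound 2 to compound 3 (0.35 log units; beyond the scatter) shows methyl in place of chloro raised it by a similar amount. With two chlorines entering and the methyl leaving, a modest drop is expected, around a 2.4-fold lower number from compound 3 to compound 4 (0.37 log units; beyond the scatter). Compound 4 is therefore estimated at 3500 nM in this assay, with a range from 1500 nM to 8500 nM.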

Compound 4, half-maximal inhibitory concentration: 3660 nM
Compound 4: the middle estimate sits 1.0-fold (0.02 log units) below what was measured, and the stated range covers the measured number.
By their numbers in this assay, from the lowest: compounds 4 and 2 (each within the scatter of the next); then compounds 3 and 1 (each within the scatter of the next).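

In this assay, 3,5-dichlorophenyl on the carbonyl carbon gives lower numbers than phenyl (a 2.3-fold lower number from compound 1 to compound 4 (0.36 log units; beyond the scatter)) and 2-methylphenyl (a 2.3-fold lower number from compound 3 to compound 4 (0.36 log units; beyond the scatter)), but it cannot be told apart from 2-chlorophenyl (a 1.0-fold lower number from compound 2 to compound 4 (0.00 log units; within the scatter)). So the two chlorines of compound 4 show no gain over the single chlorine of compound 2, and chlorine is tolerated in more than one arrangement on this ring. Nothing available explains this result.

From the compounds shown here alone, whether a methoxy group, a nitrile or an amine on this ring would lower the number further remains open.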